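Benzylsulfonyl in place of (4-bromophenyl)carbonyl on compound 3

The compounds below may be only part of what the source reports. "The series", "measured", "known", "first", "only" and "open" are said of these compounds alone.

In an ADME assay on L02 cells (Homo sapiens) for cytotoxicity, read by MTT assay (on this read-out higher numbers stand for weaker inhibition and lower numbers for stronger inhibition), compound 1 `C#CCOc1cc(/C=C/C(=O)c2ccc(OC)c3c2OC(C)(C)C=C3)ccc1OC` gives > 10000 nM as a limit of the assay. Compound 2 `CCCCC(=O)Oc1cc(/C=C/C(=O)c2ccc(OC)c3c2OC(C)(C)C=C3)ccc1OC` gives > 10000 nM and this too is a limit. Within the data shown here, compound 3 `COc1ccc(/C=C/C(=O)c2ccc(OC)c3c2OC(C)(C)C=C3)cc1OC(=O)c1ccc(Br)cc1` stands at 8400 nM and holds the only exact number so far. Compound 4 `COc1ccc(/C=C/C(=O)c2ccc(OC)c3c2OC(C)(C)C=C3)cc1OS(=O)(=O)Cc1ccccc1` has benzylsulfonyl in place of (4-bromophenyl)carbonyl on an oxygen on an aromatic ring. Among the measured compounds shown here, two measured steps bear on this oxygen, an at least 1.1-fold lower number from compound 1 to compound 3 (0.07 log units; that floor lies within the scatter) and an at least 1.1-fold lower number from compound 2 to compound 3 (0.07 log units; that floor lies within the scatter) and both are floors within the scatter. Also in view is the limit of > 10000 nM in this assay, at which 2 of the 3 values shown sit, so a plain limit may well return. The step expected in this assay is a 1.2-fold higher number from compound 3 to compound 4 (0.08 log units; within the scatter) and nothing beyond the scatter is expected in either direction. For compound 4 the estimated value is 10000 nM (expected range 5000 nM to 20000 nM).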

Compound 4, half-maximal inhibitory concentration: > 10000 nM
Compound 4 was reported as a limit; the forecaster's own chance of this, stated with the estimate: 55%; the middle value sits exactly at the limit.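

In this assay, benzylsulfonyl on this oxygen gives an at least 1.1-fold higher number from compound 3 to compound 4 (0.07 log units; that floor lies within the scatter), so this sulfonyl group cannot be told apart from (4-bromophenyl)carbonyl on this read-out. The steps from compound 1 and from compound 2 to compound 4 join two limits and cannot be read. A third group on this oxygen, benzylsulfonyl in compound 4, now ends at a limit: the limit of > 10000 nM in this assay, at which 3 of the 4 values shown sit.

On these data alone, how far the true values of compound 1, compound 2 and compound 4 lie beyond that limit remains open. Also open, as far as these compounds go, is whether an amine or a carboxylic acid on this oxygen would move the number clearly away from that of compound 3.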